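Removing the Chloro Group in Two Related Cores

This account rests on a few compounds, and the source may have more. Where it says the series, first, only, none or still open, it means among the compounds named here.

Of the compounds shown here, three have been measured in a functional assay on the whole organism for inhibition, with Scenedesmus acutus as the target; on this read-out lower numbers stand for stronger inhibition and higher numbers for weaker inhibition. Compound 1 `S=c1n(-c2ccc(Cl)cc2)c(=S)n2n1CCCC2` gives 61.7 nM. Compound 2 `S=c1n(-c2ccccc2)c(=S)n2n1CCCC2` gives 7940 nM; the change from compound 1 is hydrogen in place of chloro on an aromatic carbon, and the step is a 130-fold higher number from compound 1 to compound 2 (2.11 log units; beyond the scatter). Compound 3 `S=c1s/c(=N\c2ccc(Cl)cc2)n2n1CCCC2` has the same atoms as compound 1, joined differently; the difference between the two cores is not broken down here. In this assay compound 3 gives 339 nM. Compound 4 `S=c1s/c(=N\c2ccccc2)n2n1CCCC2` has not yet been measured; it differs from compound 3 by hydrogen in place of chloro on an aromatic carbon, the same change as between compound 1 and compound 2. Because the earlier step was a 130-fold higher number from compound 1 to compound 2 (2.11 log units; beyond the scatter), a large weakening is expected again. Resting on that, the expected step is a 59-fold higher number from compound 3 to compound 4 (1.77 log units; beyond the scatter), with the unbroken-down difference between the cores adding uncertainty. Compound 4 is therefore estimated at 20000 nM, between 3000 nM and 120000 nM.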

Compound 4, half-maximal inhibitory concentration: 14100 nM
The estimate for compound 4 lay 1.4-fold (0.15 log units) above the measured number, within the range that was stated.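

In this assay, replacing the chloro group with hydrogen again weakened inhibition, with a 42-fold higher number from compound 3 to compound 4 (1.62 log units; beyond the scatter). The change thus points the same way and stays large on both cores, but its size does not carry over unchanged: the same change on two cores in this assay, a 130-fold higher number (2.11 log units; beyond the scatter) from compound 1 to compound 2 and a 42-fold higher number (1.62 log units; beyond the scatter) from compound 3 to compound 4, 3.1-fold (0.49 log units) apart, beyond the scatter of two such steps. For the compounds shown here, with only two cores compared, this does not show how the change would behave on any further core, nor does it explain why the two steps differ in size.

Only chloro and hydrogen are compared at this place on the aromatic ring, so the compounds shown leave open whether a bromo, methyl or methoxy group there would give inhibition closer to that of chloro or of hydrogen.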